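Swapping fluoro for methoxy on the fused ring of compound 2

This account rests on a few compounds, and the source may have more. Where it says the series, first, only, none or still open, it means among the compounds named here.

Measured compounds:
- compound 1 `Cc1ccc(-c2ccc(C)n2-c2ccc(-c3nc4ccc(F)cc4s3)cc2)cc1`: 2970 nM
- compound 2 `COc1ccc(-c2ccc(C)n2-c2ccc(-c3nc4ccc(F)cc4s3)cc2)cc1`: 2550 nM
- compound 3 `Cc1ccc(-c2ccc([N+](=O)[O-])cc2)n1-c1ccc(-c2nc3ccc(F)cc3s2)cc1`: 2370 nM

In a functional assay on MCF7 cells (Homo sapiens) for cytotoxicity, read by MTT assay, with a stated time of 72 h (on this read-out lower numbers stand for stronger inhibition and higher numbers for weaker inhibition), compound 2 gives 2550 nM, the second highest of the three numbers. Its nearest neighbour is compound 3 with 2370 nM, and the furthest is compound 1 with 2970 nM; both gaps are within the scatter, so the three compounds cannot be told apart on this assay.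

Compound 4 `COc1ccc(-c2ccc(C)n2-c2ccc(-c3nc4ccc(OC)cc4s3)cc2)cc1` differs from compound 2 by methoxy in place of fluoro on an aromatic carbon. All three measured steps sit elsewhere, on the aromatic carbon of the other six-membered ring: a 1.2-fold lower number from compound 1 to compound 2 (0.07 log units; within the scatter), a 1.3-fold lower number from compound 1 to compound 3 (0.10 log units; within the scatter) and a 1.1-fold lower number from compound 2 to compound 3 (0.03 log units; within the scatter). For the measured compounds named here, none of them touches the fused ring, so no measured step bears directly on the change to compound 4. What the three steps do show is that exchanging methyl, methoxy and nitro on this shared core moved this assay by nothing beyond the scatter. With no evidence for a larger effect at the fused ring, the expected step from compound 2 to compound 4 is none beyond the scatter, estimated as a 1.0-fold higher number from compound 2 to compound 4 (0.01 log units; within the scatter). Compound 4 is therefore expected to give about 2600 nM, within a range of 1200 nM to 5600 nM.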

Compound 4, half-maximal inhibitory concentration: 4830 nM
Compound 4: the middle estimate sits 1.9-fold (0.27 log units) below what was measured; the range from low to high includes it.
By their numbers in this assay, from the lowest: compounds 3, 2, 1 and 4 (each within the scatter of the next, the first and the last beyond it).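

Compound 4 is the only compound shown with a change on the fused ring, so it gives the first reading at this position: methoxy in place of fluoro gives a 1.9-fold higher number from compound 2 to compound 4 (0.28 log units; within the scatter) in this assay and the result is still read as no real difference. Fluoro and methoxy therefore cannot be told apart at this aromatic carbon, so the fused ring, like the other six-membered ring carrying methyl, methoxy or nitro, has yet to show a change that clearly exceeds the normal spread of repeated measurements. Nothing measured here offers an explanation for the size of this step.

The compounds shown leave open whether a group of another kind at this carbon, such as an amine or a carboxylic acid, would move the number beyond the scatter. They also leave open whether the swap from fluoro to methoxy would read the same with methyl or nitro on the other ring, as the only pair shown for this swap carries methoxy there.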